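A few compounds are considered here, and "the series" means these few. Any claim that something is new, unique, unknown or untested is made for them only; others in the source may bear on it.

Measured compounds: compound 1 `CNc1ncnc2[nH]cc(Sc3cccs3)c12` gives 45300 nM in a functional assay on HCT-116 cells (Homo sapiens), read by MTT assay, with a stated time of 3 days; on this read-out higher numbers stand for weaker inhibition and lower numbers for stronger inhibition; compound 2 `c1csc(Sc2c[nH]c3ncnc(-c4cccs4)c23)c1` gives 5060 nM in this assay.

Compound 1 holds the highest number of the two; its nearest neighbour is compound 2, reached by a 9.0-fold lower number from compound 1 to compound 2 (0.95 log units; beyond the scatter), a step described as thiophen-2-yl in place of methylamino on an aromatic carbon.

Compound 3 `c1coc(-c2ncnc3[nH]cc(Sc4cccs4)c23)c1` is not yet measured in this assay. It differs from compound 1 by furan-2-yl in place of methylamino on an aromatic carbon. For the measured compounds named here, the single measured step that bears on this change is the one from compound 1 to compound 2, where a five-membered aromatic ring with one hetero atom also replaced methylamino at the same place; that step was a 9.0-fold lower number from compound 1 to compound 2 (0.95 log units; beyond the scatter). Going by the values given here, a step of comparable direction, lowering the number, is therefore expected for compound 3, with the size uncertain given only one comparison: a 6.5-fold lower number from compound 1 to compound 3 (0.81 log units; beyond the scatter). The value of compound 3 in this assay is estimated at 7000 nM, with a range from 2500 nM to 20000 nM.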

Compound 3, half-maximal inhibitory concentration: 19500 nM
Compound 3: middle estimate off by 2.8-fold (0.44 log units), on the low side; measured number inside the range.
By their numbers in this assay, from the lowest: compound 2; then compound 3; then compound 1.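

In this assay, furan-2-yl in place of methylamino on this aromatic carbon gives a 2.3-fold lower number from compound 1 to compound 3 (0.37 log units; beyond the scatter) and so joins thiophen-2-yl in lowering the number, which means the lowering is not confined to one ring. The two rings are still not interchangeable at this place, since the change between them gives a 3.9-fold higher number from compound 2 to compound 3 (0.59 log units; beyond the scatter) even though each is a five-membered aromatic ring with one hetero atom. No measured evidence here accounts for the gap between the two rings.

Going by these compounds, whether the lower number needs a five-membered aromatic ring at all remains open, and a phenyl ring or a morpholine at this place would test that. Also open, on these data alone, is whether thiophen-2-yl keeps its lead over furan-2-yl when the sulfur-linked thiophene on the shared core is replaced by another group.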